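A few compounds are considered here, and "the series" means these few. Any claim that something is new, unique, unknown or untested is made for them only; others in the source may bear on it.

Compound 1, `Fc1ccc2nc(-c3cncs3)n(C3CC3)c2c1`: 4520 nM
Compound 2, `Fc1cc2nc(-c3cncnc3)n(C3CC3)c2cc1F`: 2270 nM
Compound 3, `Cc1ncncc1-c1nc2cc(F)c(F)cc2n1C1CC1`: 4160 nM

In an ADME assay on cells for inhibition of cytochrome P450 11B1, mitochondrial (Homo sapiens), read by HPLC, with a stated time of 60 min (a higher number here means a weaker inhibitor, a lower number a stronger inhibitor), compound 3 gives 4160 nM. Going by the values given here, the three measured numbers all lie within the usual scatter of one another: compound 1 gives 4520 nM, close to compound 3, and the only single-point step among them, a 1.8-fold higher number from compound 2 to compound 3 (0.26 log units; within the scatter), is likewise within the scatter. So on the numbers shown compound 3 is neither separated from compound 1 nor from compound 2.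

Compound 4, `CCc1ncncc1-c1nc2cc(F)c(F)cc2n1C1CC1`, differs from compound 3 by methyl in place of hydrogen on a saturated chain carbon bound to an aromatic carbon. Among the compounds with values here, the one measured step that bears on it is the earlier addition of the same group one bond closer in, a 1.8-fold higher number from compound 2 to compound 3 (0.26 log units; within the scatter), which did not move the number beyond the scatter. Within the data shown here, there is no measured step for lengthening methyl to ethyl on this core, so the expectation rests on that single nearby step alone.

Compound 4 is therefore expected to stay close to compound 3, with an estimated step of a 1.0-fold higher number from compound 3 to compound 4 (0.00 log units; within the scatter), not beyond the scatter. The estimated value for compound 4 is 4200 nM, within a range from 1900 nM to 9500 nM.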

Compound 4, half-maximal inhibitory concentration: 3330 nM
Beside the measured number, compound 4's estimate is 1.3-fold (0.10 log units) above it, within the range that was stated.
By their numbers in this assay, from the lowest: compounds 2, 4, 3 and 1 (each within the scatter of the next).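

In this assay, lengthening methyl to ethyl on the saturated chain carbon bound to an aromatic carbon gives a 1.2-fold lower number from compound 3 to compound 4 (0.10 log units; within the scatter), so a second step at this position stays within the scatter. Taken from the unsubstituted aromatic carbon, the whole change of hydrogen to ethyl gives a 1.5-fold higher number from compound 2 to compound 4 (0.17 log units; within the scatter), and this is also within the scatter, as is the methyl step a 1.8-fold higher number from compound 2 to compound 3 (0.26 log units; within the scatter), so on these numbers hydrogen, methyl and ethyl at this place cannot be told apart, which a single methyl step could not show. No independent measurement is available that bears on these results.

The compounds shown leave open whether a different group on this aromatic carbon, such as an amine, a carboxylic acid or a longer chain like propyl, would give a step beyond the scatter. They also leave open whether ethyl in place of hydrogen would read the same way on the core of compound 1, since only the core shared by compound 2, compound 3 and compound 4 carries this series of groups.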